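This account rests on a few compounds, and the source may have more. Where it says the series, first, only, none or still open, it means among the compounds named here.

In a functional assay on A549 cells (Homo sapiens) for inhibition, read by MTT assay, with a stated time of 72 h (on this read-out lower numbers stand for stronger inhibition and higher numbers for weaker inhibition), two compounds have been measured so far, and neither gives a number. Compound 1 (`Nc1ccccc1NC(=O)c1ccc(CNCc2nc(-c3cccs3)no2)cc1`) reads > 100000 nM as a limit of the assay. Compound 2 (`O=C(NO)c1ccc(CNCc2nc(-c3ccc([N+](=O)[O-])cc3)no2)cc1`) reads > 100000 nM as a limit too. From the compounds shown here alone, compound 2 therefore sits at the limit of > 100000 nM in this assay, at which 2 of the 2 values shown sit, and its true position remains open.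

Compound 3 (`O=C(NO)c1ccc(CNCc2nc(-c3cccs3)no2)cc1`) is still to be measured in this assay and keeps the rest of compound 2. It carries thiophen-2-yl in place of 4-nitrophenyl on an aromatic carbon of a five-membered aromatic ring with 2 nitrogen and 1 oxygen, and thiophen-2-yl in place of 4-nitrophenyl on an aromatic carbon gives the full count of that change. Among the compounds with values here, no pair of measured compounds differs in one place, so this change has no direct precedent. Thiophen-2-yl also appears in compound 1, whose > 100000 nM is a limit and gives no number to work from. Only a small step towards stronger inhibition, or none beyond the scatter, is therefore expected. The expected change is an at least 1.2-fold lower number from compound 2 to compound 3 (0.09 log units; that floor lies within the scatter) on this estimate. For compound 3 the estimated value is 80000 nM with an expected range from 15000 nM to 150000 nM in this read-out.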

Compound 3, half-maximal inhibitory concentration: > 100000 nM
Compound 3: no number, only a limit; the forecaster's own chance of this, stated with the estimate: 55%; at least 1.2-fold (0.09 log units) between middle value and limit.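

In this assay, compound 3 reads only as a limit, as do compound 1 and compound 2, so neither the step from compound 2 to compound 3 nor the step from compound 1 to compound 3 can be read. The compounds shown leave open where each of the three truly stands, and whether exchanging 4-nitrophenyl for thiophen-2-yl changes anything: the limit of > 100000 nM in this assay, at which 3 of the 3 values shown sit.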